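The source may report more compounds than this note shows. Statements on the series, on what has been measured and on what is new or still open speak of the compounds shown alone.

Compound 1 `CCCCCCCc1cc2cn([C@H]3C[C@H](O)[C@@H](CO)O3)c(=O)nc2o1` was examined in a functional assay on HEL cells (Homo sapiens) for cytotoxicity, read by microscopy; a lower number here means that less compound is tolerated, a higher number that more compound is tolerated. In this assay compound 1 gives > 50000 nM, which is a limit of the assay and not a number. Its two companions are compound 2 `CCCCCCCCc1cc2cn([C@H]3C[C@H](O)[C@@H](CO)O3)c(=O)nc2o1` and compound 3 `C=CCCCCc1cc2cn([C@H]3C[C@H](O)[C@@H](CO)O3)c(=O)nc2o1`. In this assay compound 2 gives > 50000 nM, again a limit rather than a number. In this assay compound 3 gives > 200000 nM, likewise a limit. Accordingly the steps a step that the two limits leave unreadable from compound 1 to compound 2, a step that the two limits leave unreadable from compound 1 to compound 3 and a step that the two limits leave unreadable from compound 2 to compound 3 cannot be sized, and the whole record consists of the limit of > 50000 nM in this assay, at which 2 of the 3 values shown sit, and (the limit of > 200000 nM in this assay, at which 1 of the 3 values shown sits). Compound 4 `C=CCCCCCCc1cc2cn([C@H]3C[C@H](O)[C@@H](CO)O3)c(=O)nc2o1` carries the change (vinyl in place of methyl on a saturated chain carbon, six bonds along the chain from an aromatic carbon). The measured steps that bear on it are those starting from compound 1 and from compound 2, each unreadable, with every measured value stopping at a limit; so no step beyond the scatter can be expected in this assay, and compound 4 is expected also to stop at a limit. Compound 4 is therefore estimated at 100000 nM, within 50000 nM to 200000 nM, which corresponds to an expected step that the limit leaves unreadable from compound 1 to compound 4.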

Compound 4, minimum cytotoxic concentration: > 200000 nM
Compound 4: only a limit was reported; the forecaster's own chance of this, stated with the estimate: 85%; middle value at least 2.0-fold (0.30 log units) away from the limit.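

Within the data shown here, compound 4 also stops at a limit in this assay, so its steps from compound 1, compound 2 and compound 3 cannot be read, and no new step follows. The compounds shown leave open at what concentration, if any, these chains become cytotoxic.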